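Shortening the butyl chain of compound 3 to propyl

The source may hold more compounds than are shown below. What is called first, only, known or untested is meant among the compounds shown, and "the series" means these compounds.

Measured in an ADME assay on J774 cells (Mus musculus) for cytotoxicity; a lower number here means that less compound is needed, a higher number that more compound is needed for the effect:
- Compound 1 `COC(=O)c1c[nH]c2cc(OCCOc3ccccc3)ccc2c1=O`: > 20000 nM
- Compound 2 `COC(=O)c1c[nH]c2cc(OCCOc3ccccc3)c(Cl)cc2c1=O`: > 20000 nM
- Compound 3 `CCCCc1cc2c(=O)c(C(=O)OC)c[nH]c2cc1OCCOc1ccccc1`: > 20000 nM

Each of these readings is a limit and not a number. Compound 3 therefore offers no numerical starting point, and the series shows only (the limit of > 20000 nM in this assay, at which 3 of the 3 values shown sit).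

The next compound, compound 4 `CCCc1cc2c(=O)c(C(=O)OC)c[nH]c2cc1OCCOc1ccccc1`, differs from compound 3 by hydrogen in place of methyl on a saturated chain carbon, three bonds along the chain from an aromatic carbon, which turns butyl to propyl. For the measured compounds named here, three measured steps bear on this change: a step that the two limits leave unreadable from compound 1 to compound 2, a step that the two limits leave unreadable from compound 1 to compound 3 and a step that the two limits leave unreadable from compound 2 to compound 3. None of them has a readable size, so none gives a measure for the change in this assay. The closest is the introduction of butyl, a step that the two limits leave unreadable from compound 1 to compound 3, which left the reading at the limit. A shorter chain on the same core is thus expected to leave the reading there too. The expected step is a step that the limit leaves unreadable from compound 3 to compound 4, with no shift in either direction beyond the scatter. For compound 4 the estimated value is 25000 nM, with an expected range from 15000 nM to 40000 nM.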

Compound 4, half-maximal effective concentration: > 20000 nM
Compound 4 was reported as a limit (the forecaster's own chance of this, stated with the estimate: 90%); the middle value lies beyond the limit too.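

In this assay compound 4 gives > 20000 nM, which is a limit, so its steps from compound 1, compound 2 and compound 3 cannot be read. The compounds shown leave open how far any of the four lies from that limit, and whether any change on the shared core would give a readable number.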